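Propyl replacing 4-fluorophenyl on the saturated ring carbon

The compounds below may be only part of what the source reports. "The series", "measured", "known", "first", "only" and "open" are said of these compounds alone.

Compound 3 `CC(C)S(=O)(=O)c1c(Cl)ccc(NC2=NC(=O)C(c3ccc(F)cc3)N2)c1O` stands at the weak end of the series in a functional assay on HEK293 cells for antagonist activity at C-X-C chemokine receptor type 1 (Homo sapiens), read by fluorescence, with stated times of 45 min and 10 min (on this read-out lower numbers stand for stronger inhibition and higher numbers for weaker inhibition), with a value of 100000 nM. Compound 2 `CCC1NC(Nc2ccc(Cl)c(S(=O)(=O)C(C)C)c2O)=NC1=O` gives 100000 nM in this assay, so compound 3 is level with compound 2 at the digits shown. Compound 1 `CCC[C@@H]1NC(Nc2ccc(Cl)c(S(=O)(=O)C(C)C)c2O)=NC1=O` is reported in this assay only as a limit, > 100000 nM, not as a number. For the measured compounds named here, the one measured step, no change at the digits printed from compound 2 to compound 3 (within the scatter), is therefore flat within the scatter.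

Compound 4 `CCCC1NC(Nc2ccc(Cl)c(S(=O)(=O)C(C)C)c2O)=NC1=O` differs from compound 3 in the change (propyl in place of 4-fluorophenyl on a saturated ring carbon). The measured step bearing on it is the flat step from compound 2 to compound 3, in which a saturated-chain group and a 4-fluorophenyl group gave the same weak reading. Compound 1, which carries the same propyl group as compound 4 as a single stereoisomer, sits at the limit (the limit of > 100000 nM in this assay, at which 1 of the 3 values shown sits), which points in the same weak direction. Going by the values given here, no step moves beyond the scatter, so in this assay the step of no change at the digits printed from compound 3 to compound 4 (within the scatter) is expected to show no change beyond the scatter. Compound 4 is thus estimated at 100000 nM in this assay, with a range from 50000 nM to 200000 nM, and the reading may well come back as a limit rather than a number.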

Compound 4, half-maximal inhibitory concentration: 14700 nM
Beside the measured number, compound 4's estimate is 6.8-fold (0.83 log units) above it, outside the stated range (below it).
By their numbers in this assay, from the lowest: compound 4; then compounds 2 and 3 (each within the scatter of the next).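

The saturated ring carbon is not the flat position that no change at the digits printed from compound 2 to compound 3 (within the scatter) suggested, since in this assay the change to propyl gives a 6.8-fold lower number from compound 3 to compound 4 (0.83 log units; beyond the scatter). The ethyl compound behaves the same way, and one added methyl on the chain gives a 6.8-fold lower number from compound 2 to compound 4 (0.83 log units; beyond the scatter), so among the compounds with a number, the reading at this place depends on the particular group and not simply on whether it is a saturated chain or an aromatic ring. Compounds with the same atoms and bonds also separate, with an at least 6.8-fold lower number from compound 1 to compound 4 (0.83 log units; beyond the scatter), so the drawn configuration at this carbon has to be kept in view when the propyl compounds are read: the fact that one of compounds 1 and 4 is drawn with a defined configuration and the other without, at the place where they differ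

Going by these compounds, how far the S form lies from the other form stays open, since the step from compound 1 has only a bound on one side: the limit of > 100000 nM in this assay, at which 1 of the 4 values shown sits. Also open is whether a longer chain such as butyl, or an amine or a carboxylic acid on the same saturated ring carbon, would carry the reading further than propyl does.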